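The compounds below may be only part of what the source reports. "The series", "measured", "known", "first", "only" and "open" are said of these compounds alone.

Of the compounds shown here, three built on one shared core have been tested in an ADME assay on HepG2 cells (Homo sapiens) for cytotoxicity, read by trypan blue exclusion, with a stated time of 48 h, in the presence of a further agent that is not named here; a lower number here means that less compound is tolerated, a higher number that more compound is tolerated. Compound 1, `COc1ccccc1NC(=O)COc1cc(C)nc2ccc(C(F)(F)F)cc12`, gives only a limit of the assay, > 128000 nM. Compound 3, `COc1cc(NC(=O)COc2cc(C)nc3ccc(OC)cc23)cc(OC)c1`, likewise gives only a limit, > 131000 nM. For the measured compounds named here, compound 2, `COc1cccc(NC(=O)COc2cc(C)nc3ccc(OC)cc23)c1`, is the one compound with a definite number, 24700 nM, and so stands alone among the values shown as the only point that can be compared directly.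

Compound 4, `COc1ccc2nc(C)cc(OCC(=O)Nc3ccc(Cl)cc3)c2c1`, has not yet been measured. It differs from compound 2 by 4-chlorophenyl in place of 3-methoxyphenyl on an amide-type nitrogen. Going by the values given here, the single measured step that touches the same ring is an at least 5.3-fold higher number from compound 2 to compound 3 (0.72 log units; beyond the scatter), where the number rose into the range the assay no longer resolves; how much larger the rise really was is unknown because of the limit of > 131000 nM in this assay, at which 1 of the 3 values shown sits. Among the compounds with values here, no measured step exchanges the whole ring as this change does, and none introduces a chlorine, so the direction cannot be read from the data. Compound 4 is therefore expected to give 40000 nM, between 12000 nM and 150000 nM. The expected step is a 1.6-fold higher number from compound 2 to compound 4 (0.21 log units; within the scatter), a change that may well lie within the scatter.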

Compound 4, half-maximal cytotoxic concentration: 71100 nM
The estimate for compound 4 lay 1.8-fold (0.25 log units) below the measured number; the range from low to high includes it.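

Replacing 3-methoxyphenyl with 4-chlorophenyl on the amide-type nitrogen gives a 2.9-fold higher number from compound 2 to compound 4 (0.46 log units; beyond the scatter), so a change of the whole ring at this position has a size that can be read. The earlier rise in this assay, an at least 5.3-fold higher number from compound 2 to compound 3 (0.72 log units; beyond the scatter), came from adding a methoxy to the ring and its full size stayed unknown. Compound 4 carries a chlorine and no methoxy, so in this pair the number rises with no methoxy on the ring, and both measured steps on this ring go upward.

Any comparison of compound 4 with compound 3 cannot be read, because compound 3 gives only a limit: the limit of > 131000 nM in this assay, at which 1 of the 4 values shown sits.

Still open, as far as these compounds go, is whether the chlorine or its place on the ring matters, and how an amine or a carboxylic acid there would behave.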